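This account rests on a few compounds, and the source may have more. Where it says the series, first, only, none or still open, it means among the compounds named here.

Compound 1 `COC(=O)c1ccc(CN(CCCc2c(N)nc(N)nc2O)c2cc(F)cc(F)c2[N+](=O)[O-])cc1` was tested in a functional assay on CCRF-CEM cells (Homo sapiens) for cytotoxicity, in the absence of a further agent; a higher number here means a weaker inhibitor, a lower number a stronger inhibitor. Compound 1 gives only a limit there, > 100000 nM, the limit at which (the limit of > 100000 nM in this assay, at which 1 of the 3 values shown sits). Compound 2 `Nc1nc(N)c(CCCNc2cc(F)cc(F)c2[N+](=O)[O-])c(O)n1` carries hydrogen in place of 4-(methoxycarbonyl)benzyl on a nitrogen on an aromatic ring and in this assay compound 2 gives 97000 nM; the step is an at least 1.0-fold lower number from compound 1 to compound 2 (0.01 log units; that floor lies within the scatter). Compound 3 `COC(=O)c1ccc(CN(CCCc2c(N)nc(N)nc2O)c2ccc([N+](=O)[O-])c(F)c2F)cc1` differs from compound 1 in its core, (2,3-difluoro-4-nitrophenyl in place of 3,5-difluoro-2-nitrophenyl on an amine nitrogen), and in this assay compound 3 gives 55000 nM; the step is an at least 1.8-fold lower number from compound 1 to compound 3 (0.25 log units; that floor lies within the scatter). Compound 4 `Nc1nc(N)c(CCCNc2ccc([N+](=O)[O-])c(F)c2F)c(O)n1` is not yet measured; it stands to compound 3 as compound 2 stands to compound 1, through the same change (hydrogen in place of 4-(methoxycarbonyl)benzyl on a nitrogen on an aromatic ring). The step expected for compound 4, a 1.1-fold lower number from compound 3 to compound 4 (0.04 log units; within the scatter), is small because the same change gave an at least 1.0-fold lower number from compound 1 to compound 2 (0.01 log units; that floor lies within the scatter). Compound 4 is therefore expected to give 50000 nM in this assay, somewhere from 20000 nM to 120000 nM.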

Compound 4, half-maximal inhibitory concentration: 76000 nM
Compound 4: the middle estimate sits 1.5-fold (0.18 log units) below what was measured; the measured number falls inside the stated range.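

Putting hydrogen in place of 4-(methoxycarbonyl)benzyl gives a 1.4-fold higher number from compound 3 to compound 4 (0.14 log units; within the scatter) in this assay, so on the core of compound 3 the effect of this change cannot be told apart from ordinary assay scatter. The result for compound 1 is a limit and not a number, so the step on its core is only a floor. This means the pair shows neither that the change carries over unaltered from one core to the other nor that it fails to, as the two steps side by side make plain: the same change on two cores in this assay, an at least 1.0-fold lower number (0.01 log units; that floor lies within the scatter) from compound 1 to compound 2 and a 1.4-fold higher number (0.14 log units; within the scatter) from compound 3 to compound 4; the limit leaves it open whether they differ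

The compounds shown leave open whether a different group on that nitrogen, such as a benzyl group carrying a carboxylic acid or a simple amine-bearing chain, would give a step beyond the scatter. They also leave open whether a longer chain to the shared core would do so.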